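This account rests on a few compounds, and the source may have more. Where it says the series, first, only, none or still open, it means among the compounds named here.

Compound 1, `COc1ccc(/C(=C(/CCN)c2ccccc2)c2ccccc2)cc1`: 11400 nM
Compound 2, `COc1ccc(/C(=C(/CCNC(=O)N2CCCC2)c2ccccc2)c2ccccc2)cc1`: > 50000 nM

The two measured compounds share one core and differ only at the amine nitrogen. In a functional assay on MDA-MB-231 cells (Homo sapiens) for cytotoxicity, read by MTT assay, with a stated time of 72 h (a higher number here means a weaker inhibitor, a lower number a stronger inhibitor), compound 1 gives 11400 nM. For compound 2 the value > 50000 nM is a limit of this assay and not a number. The step of an at least 4.3-fold higher number from compound 1 to compound 2 (0.64 log units; beyond the scatter) is accordingly only a bound on the loss, resting on (the limit of > 50000 nM in this assay, at which 1 of the 2 values shown sits). Compound 2 thus stands at the weak end of the two values shown, sitting at the limit of this assay.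

Compound 3, `COc1ccc(/C(=C(/CCNC(=O)C(=O)N2CCCCC2)c2ccccc2)c2ccccc2)cc1`, is not yet measured. It differs from compound 2 by (piperidin-1-yl)carbonyl in place of pyrrolidin-1-yl on a carbonyl carbon. Among the measured compounds shown here, only one measured step bears on this change: an at least 4.3-fold higher number from compound 1 to compound 2 (0.64 log units; beyond the scatter), in which the (pyrrolidin-1-yl)carbonyl in place of hydrogen on the amine nitrogen already carried the number to the limit. Compound 3 lengthens that same cap further, so no recovery is expected. Compound 3 is therefore estimated at about 80000 nM in this assay, between 30000 nM and 200000 nM. The expected step that the limit leaves unreadable from compound 2 to compound 3 is one of no change beyond the scatter, most likely reported again as a limit.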

Compound 3, half-maximal inhibitory concentration: > 50000 nM
Compound 3: a limit, no number; the forecaster's own chance of this, stated with the estimate: 75%; the middle value does not contradict the limit.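

In this assay compound 3 gives > 50000 nM, which is a limit of the assay and not a number. Placing ((piperidin-1-yl)carbonyl)carbonyl on the amine nitrogen gives an at least 4.3-fold higher number from compound 1 to compound 3 (0.64 log units; beyond the scatter), so the loss is not confined to the (pyrrolidin-1-yl)carbonyl group, and two different groups at this nitrogen now show it. The change from compound 2 to compound 3 cannot be read, because neither compound has a number here: the limit of > 50000 nM in this assay, at which 2 of the 3 values shown sit.

The compounds shown leave open whether any group on the amine nitrogen keeps the number near that of compound 1, which gives 11400 nM, for instance a methyl or an acetyl group, or a longer chain ending in an amine or a carboxylic acid. They also leave open what the six-membered ring and the added carbonyl each contribute, since the two enter together and any difference between compound 2 and compound 3 lies hidden behind the limit.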